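The source may hold more compounds than are shown below. What is called first, only, known or untested is meant among the compounds shown, and "the series" means these compounds.

Compound 1 `CCOC(=O)c1cc(CCCOc2c(C)cc(-c3noc(C(F)(F)F)n3)cc2C)on1` gives 17200 nM in an ADME assay on HeLa cells (Homo sapiens) for cytotoxicity, read by crystal violet staining, with a stated time of 72 h; a higher number here means that more compound is tolerated, a lower number that less compound is tolerated.
Compound 2 `Cc1cc(-c2noc(C(F)(F)F)n2)cc(C)c1OCCCc1cc(C(=O)OC(C)C)no1` gives 17900 nM in this assay.
Compound 3 `CNC(=O)c1cc(CCCOc2c(C)cc(-c3noc(C(F)(F)F)n3)cc2C)on1` reaches only a limit of this assay, > 100000 nM.
Compound 4 `CCNC(=O)c1cc(CCCOc2c(C)cc(-c3noc(C(F)(F)F)n3)cc2C)on1` has not yet been measured in this assay.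

Compounds 1 and 2 share one core, compounds 3 and 4 another; the two cores differ by methylamino in place of ethoxy on a carbonyl carbon. That change brought an at least 5.8-fold higher number from compound 1 to compound 3 (0.76 log units; beyond the scatter), and compound 3 sits at the limit of > 100000 nM in this assay, at which 1 of the 3 values shown sits, so only a limit is known for it. Within each pair the change is of the same kind: methyl in place of hydrogen on a saturated chain carbon bound to an oxygen next to a carbonyl group and a saturated chain carbon in the first pair and methyl in place of hydrogen on a saturated chain carbon bound to an amide-type nitrogen in the second. The surroundings are not identical, though: in compound 1 the carbon that gains the methyl is bound to an oxygen next to a carbonyl group and a saturated chain carbon, whereas in compound 3 it is bound to an amide-type nitrogen. The measured step was a 1.0-fold higher number from compound 1 to compound 2 (0.02 log units; within the scatter). A similarly small step is expected in this assay, a step that the limit leaves unreadable from compound 3 to compound 4, resting on a 1.0-fold higher number from compound 1 to compound 2 (0.02 log units; within the scatter). Compound 4 is therefore estimated at 150000 nM, from 60000 nM to 400000 nM, most likely again reported only as a limit.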

Compound 4, half-maximal cytotoxic concentration: > 100000 nM
Compound 4 was reported as a limit; the forecaster's own chance of this, stated with the estimate: 75%; the middle value is on the limit's open side.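

In this assay compound 4 is reported only as a limit, > 100000 nM. Adding the methyl to the saturated chain carbon bound to an amide-type nitrogen gave a 1.0-fold higher number from compound 1 to compound 2 (0.02 log units; within the scatter) on the other core, but the corresponding step from compound 3 to compound 4 cannot be read, so that small step is neither confirmed nor contradicted on this core, because both compounds stand at the same limit: the limit of > 100000 nM in this assay, at which 2 of the 4 values shown sit. What can be read is an at least 5.8-fold higher number from compound 1 to compound 4 (0.76 log units; beyond the scatter), and likewise an at least 5.5-fold higher number from compound 2 to compound 4 (0.74 log units; beyond the scatter).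

The compounds shown leave open how far beyond the limit compound 3 and compound 4 lie, and so whether they differ at all. A longer chain on the amide nitrogen, such as butylamino, or a hydroxy group in place of the ethoxy on the carbonyl carbon, giving a carboxylic acid, could show whether a readable number returns.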